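Cytotoxicity of chalcone analogues in CHO cells

The compounds below may be only part of what the source reports. "The series", "measured", "known", "first", "only" and "open" are said of these compounds alone.

Measured compounds:
compound 1 `O=C(/C=C/c1cccc(OCc2ccccc2)c1)c1ccc([N+](=O)[O-])cc1` — 82400 nM
compound 2 `O=C(/C=C/c1cccc(OCc2ccccc2)c1)c1ccc(Cl)cc1` — 43600 nM

The study records two compounds in an ADME assay on CHO cells (Cricetulus griseus) for cytotoxicity, read by MTT assay, with a stated time of 68 h; on this read-out higher numbers stand for weaker inhibition and lower numbers for stronger inhibition. Compound 1 gives 82400 nM, the highest of the two numbers; its nearest neighbour is compound 2, which gives 43600 nM. For the measured compounds named here, the single measured step, a 1.9-fold lower number from compound 1 to compound 2 (0.28 log units; within the scatter), is within the scatter, so the two values cannot be ordered.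

Compound 3 `O=C(/C=C/c1cccc(OCc2ccccc2)c1)c1cccc(Br)c1` has not yet been measured. It differs from compound 1 in one place: 3-bromophenyl in place of 4-nitrophenyl on a carbonyl carbon. Going by the values given here, the only step that bears on this change is a 1.9-fold lower number from compound 1 to compound 2 (0.28 log units; within the scatter), which also removes the nitro group from the aromatic ring on the carbonyl carbon and was within the scatter. A halogen on the same ring therefore gives no ground to expect a shift beyond the scatter in this assay. The estimate for compound 3 is 50000 nM, within 20000 nM to 125000 nM, meaning an expected step of a 1.6-fold lower number from compound 1 to compound 3 (0.22 log units; within the scatter).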

Compound 3, half-maximal inhibitory concentration: 9200 nM
Beside the measured number, compound 3's estimate is 5.4-fold (0.74 log units) above it; the whole stated range lies above it.
By their numbers in this assay, from the lowest: compound 3; then compounds 2 and 1 (each within the scatter of the next).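

In this assay, the group on the carbonyl carbon proves able to move the number beyond the scatter: 3-bromophenyl in place of 4-nitrophenyl gives a 9.0-fold lower number from compound 1 to compound 3 (0.95 log units; beyond the scatter) and the shift is not confined to the loss of the nitro group. The same group in place of 4-chlorophenyl gives a 4.7-fold lower number from compound 2 to compound 3 (0.68 log units; beyond the scatter) even though both rings carry a halogen, so the earlier chloro-for-nitro step, which stayed within the scatter, did not speak for every halogen-bearing ring at this place. No measurement given here accounts for this shift.

Compared with the 4-chlorophenyl group, the 3-bromophenyl group changes both the halogen and its place on the ring, so the compounds shown leave open which of the two carries the shift. As far as these compounds go, how an amine or a carboxylic acid on this ring would read also remains open.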